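A few compounds are considered here, and "the series" means these few. Any claim that something is new, unique, unknown or untested is made for them only; others in the source may bear on it.

In a physicochemical assay for solubility, in phosphate buffer, at pH 7.4 (a lower number here means a less soluble compound, a higher number a more soluble compound), compound 1 (`CCOC(=O)c1c(-c2ccccc2C)[nH]c2cc(OC)ccc2c1=O`) reads > 100000 nM, which is a limit and not a number. Compound 2 (`CCOC(=O)c1c(-c2ccccc2)[nH]c2cccc(OC)c2c1=O`) reads > 100000 nM, also a limit. Compound 3 (`CCOC(=O)c1c(-c2ccccc2Cl)[nH]c2cccc(OC)c2c1=O`) reads > 100000 nM, again a limit. The picture so far is the limit of > 100000 nM in this assay, at which 3 of the 3 values shown sit. Compound 4 (`CCOC(=O)c1c(-c2cccs2)[nH]c2cc(OC)ccc2c1=O`), not yet measured, has thiophen-2-yl in place of the 2-methylphenyl of compound 1: thiophen-2-yl in place of 2-methylphenyl on an aromatic carbon. Among the compounds with values here, the only measured step, a step that the two limits leave unreadable from compound 2 to compound 3, concerns a different change, chloro in place of hydrogen, and offers no size to carry over. No shift in either direction beyond the usual scatter is therefore expected in this assay, and the expected change is a number no higher from compound 1 to compound 4 (the limit leaves the size open). For compound 4 the estimate is 100000 nM, with an expected range of 50000 nM to 200000 nM.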

Compound 4, solubility: > 100000 nM
Compound 4 was reported as a limit; the forecaster's own chance of this, stated with the estimate: 80%; the middle value sits exactly at the limit.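

Compound 1 and compound 4 are both reported in this assay as limits and not numbers, so the step between them cannot be read. How far apart the compounds shown really lie stays open, with all of them at one reading: the limit of > 100000 nM in this assay, at which 4 of the 4 values shown sit.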